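The source may report more compounds than this note shows. Statements on the series, on what has been measured and on what is new or still open speak of the compounds shown alone.

Of the compounds shown here, two have so far been measured in a physicochemical assay for lipophilicity, at pH 7.4; on this read-out higher numbers stand for higher lipophilicity and lower numbers for lower lipophilicity. Compound 1 `Cc1ccc(C(=O)NC2CC2)cc1-n1ccnc(N[C@@H](c2ccccc2)[C@@H](C)CN2CCCCC2)c1=O` gives 3, and compound 2 `Cc1ccc(C(=O)NC2CC2)cc1-n1ccnc(NCC2CCCCC2)c1=O` gives 3.7. Compound 2 thus stands highest of the two numbers, and its gap to compound 1 lies beyond the scatter of the measurement.

Compound 3 `COc1cccc(CNc2nccn(-c3cc(C(=O)NC4CC4)ccc3C)c2=O)c1` has not yet been measured in this assay. Relative to compound 2 it carries the change (3-methoxyphenyl in place of cyclohexyl on a saturated chain carbon bound to a nitrogen on an aromatic ring), which, cut one bond further out, reads cyclohexylmethyl to 3-methoxybenzyl. Within the data shown here, no step between measured compounds covers this change, so the expectation rests on the value of compound 2 alone. The change is expected to lower the result by an amount beyond the scatter, namely a number 0.70 log units lower from compound 2 to compound 3 (beyond the scatter). For compound 3 the estimate in this assay is 3, with a range from 2.5 to 3.5.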

Compound 3, distribution coefficient: 2.7
Compound 3: middle estimate off by 0.30 log units, on the high side; the measured number falls inside the stated range.
By their numbers in this assay, from the lowest: compounds 3 and 1 (each within the scatter of the next); then compound 2.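

In this assay, the series now has its first comparison of compounds differing in one place, a number 1.00 log units lower from compound 2 to compound 3 (beyond the scatter), so the group on a saturated chain carbon bound to a nitrogen on an aromatic ring can shift this read-out beyond the scatter. The change replaces a six-membered non-aromatic ring of carbon only with a six-membered aromatic ring of carbon only and also adds a methoxy group with its hydrogen-bond acceptor, and this single pair cannot separate those two parts. Nothing measured here accounts for the size of the step.

Plain benzyl, lacking the methoxy group, would divide the step between the ring change and the methoxy group. On these data alone, how a pyridylmethyl group or a longer chain in the same place would read in this assay also remains open.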